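The source may report more compounds than this note shows. Statements on the series, on what has been measured and on what is new or still open speak of the compounds shown alone.

Measured so far in an ADME assay on MT4 cells (Homo sapiens) for cytotoxicity, read by MTT assay; a lower number here means that less compound is tolerated, a higher number that more compound is tolerated:
- Compound 1 `CCCCCOc1ccc(C(=O)N(C(=S)OCCN2C(=O)c3ccccc3C2=O)c2ccc(F)cc2)cc1`: > 100000 nM (a limit of the assay, not a number)
- Compound 2 `O=C1c2ccccc2C(=O)N1CCOC(=S)N(C(=O)c1ccccc1[N+](=O)[O-])c1ccc(Cl)cc1`: 21000 nM
- Compound 3 `Cc1cccc(C(=O)N(C(=S)OCCN2C(=O)c3ccccc3C2=O)c2ccc(Cl)cc2)c1`: 58000 nM

Compound 2 gives the lower of the two actual numbers, and its nearest neighbour is compound 3. Compound 1 offers only a limit, so it cannot be placed exactly against them.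

The step of interest leads from compound 2 to compound 4 `Cc1ccc(C(=O)N(C(=S)OCCN2C(=O)c3ccccc3C2=O)c2ccc(Cl)cc2)cc1`, which has not yet been measured. The change is 4-methylphenyl in place of 2-nitrophenyl on a carbonyl carbon. Among the measured compounds shown here, one measured step bears on it: a 2.8-fold higher number from compound 2 to compound 3 (0.44 log units; beyond the scatter). There, 2-nitrophenyl leaves the same place and 3-methylphenyl enters. For the measured compounds named here, with only this single modest step as a guide, a rise of similar size in this assay is expected, meaning that more compound would be tolerated. The expected change is a 2.6-fold higher number from compound 2 to compound 4 (0.42 log units; beyond the scatter). Compound 4 is estimated at 55000 nM, with an expected range from 28000 nM to 100000 nM.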

Compound 4, half-maximal cytotoxic concentration: > 100000 nM
Compound 4 was reported as a limit; the forecaster's own chance of this, stated with the estimate: 15%; middle value at least 1.8-fold (0.25 log units) away from the limit.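

In this assay, 4-methylphenyl in place of 2-nitrophenyl on the carbonyl carbon gives an at least 4.7-fold higher number from compound 2 to compound 4 (0.67 log units; beyond the scatter), so a second methylphenyl group, and not only the 3-methylphenyl of compound 3, carries a higher number than the 2-nitrophenyl of compound 2. Moving between the two methylphenyl groups gives an at least 1.7-fold higher number from compound 3 to compound 4 (0.23 log units; that floor lies within the scatter), so compound 3 and compound 4 cannot be put in order in this assay. The result for compound 4 is a limit of the assay and not a number, so the full size of both steps stays unknown: the limit of > 100000 nM in this assay, at which 2 of the 4 values shown sit.

On these data alone, it remains open whether the higher numbers follow from the methyl group or merely from the loss of 2-nitrophenyl, and a plain phenyl at this carbonyl carbon would bear on that. A 4-nitrophenyl there would likewise show whether the nitro group itself or its place in the ring matters.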